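A few compounds are considered here, and "the series" means these few. Any claim that something is new, unique, unknown or untested is made for them only; others in the source may bear on it.

Compound 1 `O=C(CCl)NC(=O)Nc1ccc(OC2CCCCC2)cc1` carries a chloroacetyl urea on a benzene ring that also bears a cyclohexyloxy group. In a functional assay on M21 cells (Homo sapiens) for inhibition, read by sulforhodamine B assay, with a stated time of 48 h (a higher number here means a weaker inhibitor of growth, a lower number a stronger inhibitor of growth), compound 1 gives 5000 nM. Compound 2 `O=C(CCl)NC(=O)Nc1cccc(OC2CCCCC2)c1` is built from the same atoms joined differently; the difference between the two cores is not broken down here. In this assay compound 2 gives 2700 nM, and the two values of compound 1 and compound 2 lie within the usual scatter of each other, so no order between them can be claimed.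

Compound 3 `O=C(CCl)NC(=O)Nc1ccc(OC2CCCCCC2)cc1` is compound 1 with the change (cycloheptyl in place of cyclohexyl on an oxygen on an aromatic ring). In this assay compound 3 gives 5000 nM. The step of no change at the digits printed from compound 1 to compound 3 (within the scatter) shows that the enlarged ring on the oxygen left the growth-inhibiting concentration essentially where it was.

Compound 4 `O=C(CCl)NC(=O)Nc1cccc(OC2CCCCCC2)c1` is compound 2 with the change (cycloheptyl in place of cyclohexyl on an oxygen on an aromatic ring). The place of the change reads the same, word for word, as for the change from compound 1 to compound 3, so it is the same change, made on the core of compound 2 instead of the core of compound 1.

Because no change at the digits printed from compound 1 to compound 3 (within the scatter) amounted to no change within the scatter, the step of a 1.0-fold higher number from compound 2 to compound 4 (0.02 log units; within the scatter) is expected to be of the same size, that is, essentially none. Compound 4 is therefore estimated to give 2800 nM in this assay, with a likely range from 1200 nM to 7000 nM. This expectation rests on a single measured step, so the range is kept wide.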

Compound 4, concentration for 50% growth inhibition: 4200 nM
For compound 4 the middle estimate is 1.5-fold (0.18 log units) below the measured one; low and high end bracket the measured number.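

In this assay, going by these compounds alone, putting cycloheptyl in place of cyclohexyl on the oxygen gives a 1.6-fold higher number from compound 2 to compound 4 (0.19 log units; within the scatter), so on this second core the larger ring again produces no step that can be told apart from the ordinary spread of repeat measurements. Set side by side, the two steps agree, and the change looks the same on both cores as far as these compounds can tell: the same change on two cores in this assay, no change at the digits printed (within the scatter) from compound 1 to compound 3 and a 1.6-fold higher number (0.19 log units; within the scatter) from compound 2 to compound 4, 1.6-fold (0.19 log units) apart, within the scatter of two such steps. This agreement is a modest finding, however: it rests on just two pairs of compounds, neither step stands out from the scatter, and a small real difference between the cores could be hidden within that scatter, so it gives no general rule for other cores or other changes.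

The compounds shown leave open how growth inhibition responds to a more distinct group on the oxygen, such as a cyclopentyl ring, a straight hexyl chain, or a ring carrying an amine or a carboxylic acid. They also leave open what happens when the chloroacetyl group on the urea is replaced, for example by a plain acetyl group.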